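Working notes on a small reporter-assay series

The compounds below may be only part of what the source reports. "The series", "measured", "known", "first", "only" and "open" are said of these compounds alone.

All values come from an assay on HepG2 cells for agonist activity at nuclear receptor subfamily 1 group I member 3 (Homo sapiens), read by a luciferase reporter, with a stated time of 23 h; on this read-out lower numbers stand for an effect already at smaller amounts and higher numbers for an effect only at larger amounts of compound.

compound 1 `Cc1ccc(-c2nc3sccn3c2/C=N/OCc2ccc(Cl)c(Cl)c2)cc1`: 490 nM
compound 2 `FC(F)(F)c1ccc(CO/N=C/c2c(-c3ccc4ccccc4c3)nc3occn23)cc1`: 470 nM
compound 3 `C(=N/OC1Cc2ccccc2C1)\c1c(-c2ccc3ccccc3c2)nc2occn12`: 980 nM

Compound 1 holds the second highest of the three numbers; compound 2 sits within the scatter of it, and compound 3 also lies within the scatter, so no order among the three can be read. Among the measured compounds shown here, no pair of measured compounds differs in a single place, so no measured step is in hand. Compound 4 `Clc1cccc(-c2nc3sccn3c2/C=N/OCc2ccc(Cl)c(Cl)c2)c1` has not been measured. It differs from compound 1 by 3-chlorophenyl in place of 4-methylphenyl on an aromatic carbon. With nothing in the series to tie this change to a shift in the read-out, the step of a 1.0-fold higher number from compound 1 to compound 4 (0.01 log units; within the scatter) is expected to stay within the scatter. Compound 4 is therefore estimated at 500 nM, in the range 200 nM to 1300 nM.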

Compound 4, half-maximal effective concentration: 1100 nM
Beside the measured number, compound 4's estimate is 2.2-fold (0.34 log units) below it, within the range that was stated.
By their numbers in this assay, from the lowest: compounds 2, 1, 3 and 4 (each within the scatter of the next, the first and the last beyond it).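

Among the compounds shown here, replacing 4-methylphenyl with 3-chlorophenyl on the aromatic carbon of the shared core gives a 2.2-fold higher number from compound 1 to compound 4 (0.35 log units; beyond the scatter) in this assay, the first single-place step. This position therefore does not treat the two substituted phenyl groups alike, even though both carry no hydrogen-bond donors or acceptors. Nothing available explains the shift.

The step changes the substituent and its place on the phenyl ring together, and this single pair cannot separate the two. On these data alone, how the read-out responds to an amine or a carboxylic acid on that phenyl ring remains open.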